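Adding a Second Chloro Group: An Expected Gain in Potency

The compounds below may be only part of what the source reports. "The series", "measured", "known", "first", "only" and "open" are said of these compounds alone.

Three compounds have been measured in a functional assay on CAKI-1 cells (Homo sapiens) for cytotoxicity, read by sulforhodamine B assay, with a stated time of 48 h; on this read-out lower numbers stand for stronger inhibition of growth and higher numbers for weaker inhibition of growth:
compound 1, `ClCc1ccccc1Cn1cnc2c(Cl)nc(Cl)nc21`, gives 890 nM
compound 2, `ClCc1ccccc1Cn1cnc2c(Cl)ncnc21`, gives 4170 nM
compound 3, `ClCc1cccc(Cn2cnc3ncnc(Cl)c32)c1`, gives 4070 nM

Compound 2 and compound 1 share a core and differ in one place: chloro in place of hydrogen on an aromatic carbon. That single change brought a 4.7-fold lower number from compound 2 to compound 1 (0.67 log units; beyond the scatter), a step that stands clearly beyond the usual scatter of this kind of measurement.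

Compound 3 is built from the same atoms as compound 2, joined differently; the difference between the two cores is not broken down here. What the two values show is that compound 3 and compound 2 sit within the scatter of each other in this assay, so no order between them can be claimed.

Compound 4, `ClCc1cccc(Cn2cnc3nc(Cl)nc(Cl)c32)c1`, has not yet been measured. It stands to compound 3 as compound 1 stands to compound 2: chloro in place of hydrogen on an aromatic carbon. The surroundings of the change are the same in both pairs, so this is the same change seen once before.

Because the earlier change gave a 4.7-fold lower number from compound 2 to compound 1 (0.67 log units; beyond the scatter), a step of similar size is expected here, estimated as a 4.1-fold lower number from compound 3 to compound 4 (0.61 log units; beyond the scatter). Resting on that single precedent, compound 4 is expected to give about 1000 nM in this assay, with a likely range from 400 nM to 2500 nM.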

Compound 4, concentration for total growth inhibition: 3460 nM
Compound 4: middle estimate off by 3.5-fold (0.54 log units), on the low side; measured number outside the range, above it.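

In this assay, the chloro group did not repeat its earlier effect on the second core: a 1.2-fold lower number from compound 3 to compound 4 (0.07 log units; within the scatter) is a step within the scatter, so compound 3 and compound 4 cannot be placed in any order. The same replacement of a hydrogen by a chloro group therefore cannot be treated as a fixed gain that carries unchanged from one core to the other in this series, and what it does depends on the core that carries it: the same change on two cores in this assay, a 4.7-fold lower number (0.67 log units; beyond the scatter) from compound 2 to compound 1 and a 1.2-fold lower number (0.07 log units; within the scatter) from compound 3 to compound 4, 4.0-fold (0.60 log units) apart, beyond the scatter of two such steps These two pairs do not show which difference between the cores is responsible, and they are too few to predict what the change would do on a third core.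

The compounds shown carry only hydrogen or chloro on the aromatic carbon between two ring nitrogen atoms, which leaves open what an amine or a methoxy group would do at that place on either core. Also open, from the compounds shown here alone, is whether the two cores would respond as differently in other cells, since all of these results come from a single cell line.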